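The source may report more compounds than this note shows. Statements on the series, on what has been measured and on what is new or still open speak of the compounds shown alone.

For the measured compounds named here, compound 1, whose structure is `C[Se]/C(=N\C(=O)c1cc2ccccc2s1)NC(=O)c1cc2ccccc2s1`, is the one member of this small series for which a number was obtained in a functional assay on MCF7 cells (Homo sapiens) for cytotoxicity, read by MTT assay, with a stated time of 72 h (on this read-out lower numbers stand for higher toxicity in this test and higher numbers for lower toxicity in this test), where compound 1 gives 80600 nM. The companion compound 2, with the structure `CS/C(=N\C(=O)c1cnc2ccccc2c1)NC(=O)c1cnc2ccccc2c1`, is a different case. In this assay compound 2 reaches only the limit of the assay, > 100000 nM, so no number can be set against it; this is the limit of > 100000 nM in this assay, at which 1 of the 2 values shown sits. Going by the values given here, compound 1 therefore stands alone as the sole measured value, and a weak one, since the result lies far towards the less toxic end of the read-out.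

The next compound, compound 3, has the structure `O=C(/N=C(/NC(=O)c1cc2ccccc2s1)[Se]Cc1ccccc1)c1cc2ccccc2s1`. It differs from compound 1 in a single place: phenyl in place of hydrogen on a saturated chain carbon bound to a selenium atom. Among the compounds with values here, no pair of measured compounds in this set shares that kind of change, so its effect cannot be read from the data at hand and must be guessed.

From compound 1 to compound 3 the step expected in this assay is a 2.0-fold lower number from compound 1 to compound 3 (0.30 log units; within the scatter), a modest move towards stronger toxicity. Compound 3 is therefore estimated to give 40000 nM, with a plausible range from 10000 nM to 120000 nM.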

Compound 3, concentration lethal to 50% of the cells: 87900 nM
The estimate for compound 3 lay 2.2-fold (0.34 log units) below the measured number; the measured number falls inside the stated range.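

Moving from methyl to benzyl, with phenyl in place of hydrogen on a saturated chain carbon bound to a selenium atom, gives a 1.1-fold higher number from compound 1 to compound 3 (0.04 log units; within the scatter) in this assay, so the two compounds cannot be told apart on this read-out. For the compounds shown here, the earlier compounds offered no pair differing in one place, and this step is the first reading at this position: here a group of 6 heavy atoms, with its six-membered aromatic ring, can be added on the selenium side without taking the compound out of the weak end of the read-out. Nothing shown accounts for why this large addition leaves the number within the scatter.

From the compounds shown here alone, what remains open is whether any other group at this position would produce a step beyond the scatter, for example an amine or a carboxylic acid on the saturated chain, or a longer chain such as butyl in place of the methyl. Also open, going by these compounds, is the effect of sulfur in place of selenium with the rest of compound 1 kept the same.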